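Iodo for Fluoro on a Second Chain Length

The source may report more compounds than this note shows. Statements on the series, on what has been measured and on what is new or still open speak of the compounds shown alone.

In a functional assay on PC-3 cells (Homo sapiens) for inhibition, read by sulforhodamine B assay, with a stated time of 48 h, tested at 50 uM (a lower number here means less inhibition of growth, a higher number more inhibition of growth at the concentration tested), the measured compounds stand as follows: compound 1 `O=C1C(=O)N(CCCn2cc(COc3cc(=O)oc4ccccc34)nn2)c2ccc(I)cc21` gives 14%; compound 2 `O=C1C(=O)N(CCCn2cc(COc3cc(=O)oc4ccccc34)nn2)c2ccc(F)cc21` gives 20%; compound 3 `O=C1C(=O)N(CCCCn2cc(COc3cc(=O)oc4ccccc34)nn2)c2ccc(F)cc21` gives 17%.

Compound 3 differs from compound 2 in more than one place, and the difference between the two cores is not broken down here; their two values lie within the scatter of each other. Between compound 2 and compound 1 one change is made, (iodo in place of fluoro on an aromatic carbon), and it produced a number 6 percentage points lower from compound 2 to compound 1 (within the scatter).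

Compound 4 `O=C1C(=O)N(CCCCn2cc(COc3cc(=O)oc4ccccc34)nn2)c2ccc(I)cc21` has not yet been tested in this assay. It differs from compound 3 by iodo in place of fluoro on an aromatic carbon, the same change as that from compound 2 to compound 1, at a place described in the same words. Beside the earlier step, the step of a number 4 percentage points lower from compound 3 to compound 4 (within the scatter) is expected, resting on the value of compound 3, 17%, and on the earlier step of a number 6 percentage points lower from compound 2 to compound 1 (within the scatter). Compound 4 is therefore estimated to give 13% in this assay, with a likely range from 4% to 23%.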

Compound 4, percent growth inhibition at one concentration: 10%
Compound 4: middle estimate off by 3 percentage points, on the high side, and the stated range covers the measured number.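

Carried to the second core, iodo in place of fluoro on an aromatic carbon gave in this assay a number 7 percentage points lower from compound 3 to compound 4 (within the scatter). Set beside the earlier step, the change behaves alike on the two cores: the same change on two cores in this assay, a number 6 percentage points lower (within the scatter) from compound 2 to compound 1 and a number 7 percentage points lower (within the scatter) from compound 3 to compound 4, 1 percentage points apart, within the scatter of two such steps. This shows that the small step seen on the first core recurs on the second, but because each step lies within the scatter, neither can be told from no effect, so the agreement shows no real influence of the change that carries over, and two cores at a single tested concentration say nothing about other cores in the series.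

The compounds shown leave open what chloro, bromo or a methoxy group would give at this same place on the aromatic ring, since only fluoro and iodo stand there. They also leave open whether a longer chain would alter the picture, and whether the same change would give a step beyond the scatter on a core that carries it.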